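The source may hold more compounds than are shown below. What is called first, only, known or untested is meant among the compounds shown, and "the series" means these compounds.

Among the compounds with values here, compound 1, `COc1ccc(-c2cc(-c3ccc(S(N)(=O)=O)cc3)cnc2N)cn1`, stands lowest of the two compounds measured so far: in a physicochemical assay for lipophilicity, at pH 7.4 (on this read-out higher numbers stand for higher lipophilicity and lower numbers for lower lipophilicity), compound 1 gives 1.8, while compound 2, `COc1ccc(-c2cc(-c3ccc(S(C)(=O)=O)cc3C(F)(F)F)cnc2N)cn1`, gives 2.7, a number that lies beyond the scatter above it. Compound 3, `COc1ccc(-c2cc(-c3ccc(C(N)=O)cc3)cnc2N)cn1`, differs from compound 1 in one place: carbamoyl in place of sulfamoyl on an aromatic carbon. Within the data shown here, no measured pair shows this exchange. A small rise in this assay is expected, so that the step of a number 0.30 log units higher from compound 1 to compound 3 (within the scatter) stays close to the scatter. Compound 3 is therefore estimated at 2.1, with a range from 1.7 to 2.5.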

Compound 3, distribution coefficient: 1.7
Compound 3: the middle estimate sits 0.40 log units above what was measured; the measured number falls inside the stated range.
By their numbers in this assay, from the lowest: compounds 3 and 1 (each within the scatter of the next); then compound 2.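

In this assay, carbamoyl in place of sulfamoyl on an aromatic carbon, para to a large group, gives a number 0.10 log units lower from compound 1 to compound 3 (within the scatter), so on this read-out the two groups cannot be told apart at this position. Within the data shown here, this pair is the first to differ at this position alone, and it isolates the exchange in a way the earlier compounds could not. No measurement shown here offers an explanation for the result. Going by these compounds, it remains open whether a carboxylic acid, a nitrile or an amine in this place would also stay within the scatter of compound 1.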